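A few compounds are considered here, and "the series" means these few. Any claim that something is new, unique, unknown or untested is made for them only; others in the source may bear on it.

Measured so far in a functional assay on NCI-H661 cells (Homo sapiens) for antiproliferative activity, read by MTT assay, with a stated time of 72 h; on this read-out higher numbers stand for weaker inhibition and lower numbers for stronger inhibition
- compound 1 `Nc1ccccc1NC(=O)CCCCCCc1nc(-c2ccccc2)no1` gives 960 nM
- compound 2 `Nc1ccccc1NC(=O)CCCCCCc1nc(-c2ccc(C(F)(F)F)cc2)no1` gives 29800 nM
- compound 3 `O=C(CCCCCCc1nc(-c2ccccc2)no1)C(F)(F)F` gives 520 nM

Compound 3 shares the low end of these numbers with compound 1, since a 1.8-fold lower number from compound 1 to compound 3 (0.27 log units; within the scatter) stays within the scatter, while compound 2 reads far higher. Compound 4 `O=C(CCCCCCc1nc(-c2ccc([N+](=O)[O-])cc2)no1)C(F)(F)F` is compound 3 with a single change, nitro in place of hydrogen on an aromatic carbon, para to a large group (nitro in place of hydrogen on an aromatic carbon). The nearest guide is a 31-fold higher number from compound 1 to compound 2 (1.49 log units; beyond the scatter) where trifluoromethyl replaced hydrogen on an aromatic carbon. That guide involves another entering group and another group on the carbonyl, so only part of its size is expected to carry over in this assay towards a higher number. The expected step is a 4.8-fold higher number from compound 3 to compound 4 (0.68 log units; beyond the scatter) as a rough guess. The estimate for compound 4 is 2500 nM (400 nM to 15000 nM).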

Compound 4, half-maximal inhibitory concentration: 17500 nM
Beside the measured number, compound 4's estimate is 7.0-fold (0.85 log units) below it; the whole stated range lies below it.
By their numbers in this assay, from the lowest: compounds 3 and 1 (each within the scatter of the next); then compounds 4 and 2 (each within the scatter of the next).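

Putting nitro on the aromatic ring, para to a large group, gives a large step in this assay (a 34-fold higher number from compound 3 to compound 4 (1.53 log units; beyond the scatter)). Alongside the earlier step (a 31-fold higher number from compound 1 to compound 2 (1.49 log units; beyond the scatter)), this shows that the rise at this place is not confined to trifluoromethyl as the entering group or to the (2-aminophenyl)amino group on the carbonyl. No measurement given here explains the rise.

The compounds shown leave open whether a methoxy group or an amine at this place would also raise the number. They also leave open how nitro would behave with the (2-aminophenyl)amino group on the carbonyl.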